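Octyl swapped for 4-propylphenyl: a toxicity estimate

The compounds below may be only part of what the source reports. "The series", "measured", "known", "first", "only" and "open" are said of these compounds alone.

- Compound 1 `CCCCCCCCC#Cc1cn([C@@H]2O[C@H](CO)[C@@H](O)[C@@H]2O)c(=O)[nH]c1=O`: > 100 ug/mL
- Compound 2 `CCCCCCCCCCCC#Cc1cn([C@@H]2O[C@H](CO)[C@@H](O)[C@@H]2O)c(=O)[nH]c1=O`: > 100 ug/mL
- Compound 3 `CCCCCCCCCCCCC#Cc1cn([C@@H]2O[C@H](CO)[C@@H](O)[C@@H]2O)c(=O)[nH]c1=O`: > 100 ug/mL

In a toxicity assay on cells (Fibroblast, Homo sapiens) for cytotoxicity, read by MTT assay, with a stated time of 3 days (on this read-out lower numbers stand for higher toxicity in this test and higher numbers for lower toxicity in this test), compound 1 gives > 100 ug/mL, which is a limit and not a number. The other two measured compounds stop at the same point: the limit of > 100 ug/mL in this assay, at which 3 of the 3 values shown sit. Compound 4 `CCCc1ccc(C#Cc2cn([C@@H]3O[C@H](CO)[C@@H](O)[C@@H]3O)c(=O)[nH]c2=O)cc1` is not yet measured, and it differs from compound 1 as follows: 4-propylphenyl in place of octyl on a triple-bonded carbon. The measured chain steps bear on this change, yet none has a readable size: a step that the two limits leave unreadable from compound 1 to compound 2, a step that the two limits leave unreadable from compound 1 to compound 3 and a step that the two limits leave unreadable from compound 2 to compound 3. Within the data shown here, no measured compound carries 4-propylphenyl, so the evidence is indirect. No step beyond the scatter is expected, in either direction, and the estimated change is a step that the limit leaves unreadable from compound 1 to compound 4. That expectation rests on compound 3, which still gives > 100 ug/mL, again a limit. For compound 4 the estimated value is 110 ug/mL, with an expected range from 40 ug/mL to 200 ug/mL.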

Compound 4, half-maximal cytotoxic concentration: > 100 ug/mL
Compound 4 gave a limit, no number; the forecaster's own chance of this, stated with the estimate: 75%; the middle value lies beyond the limit too.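

Compound 1 and compound 4 both end at a limit rather than a number, so the step between them cannot be read: the limit of > 100 ug/mL in this assay, at which 4 of the 4 values shown sit. Going by these compounds, whether octyl and 4-propylphenyl differ in toxicity at all remains open.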